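A few compounds are considered here, and "the series" means these few. Any claim that something is new, unique, unknown or untested is made for them only; others in the source may bear on it.

Measured compounds:
Compound 1 `CN1CCN(CCCCCCn2c3c(c4ccccc42)C(=O)c2c[n+]([O-])c4ccccc4c2C3=O)CC1` — in a functional assay on SH-SY5Y cells (Homo sapiens) for cytotoxicity, read by MTT assay, with a stated time of 72 h (on this read-out lower numbers stand for stronger inhibition and higher numbers for weaker inhibition), compound 1 gives 920 nM.
Compound 2 `CC1(C)O[C@@H](CO)[C@H](Cn2cc(Cn3c4c(c5ccccc53)C(=O)c3c[n+]([O-])c5ccccc5c3C4=O)nn2)O1` — in this assay compound 2 gives > 1000 nM.

Compound 2 stands at the edge of what this assay reports: its value of > 1000 nM is a limit of the assay and not a measured number. This is the same limit that appears in the limit of > 1000 nM in this assay, at which 1 of the 2 values shown sits. Among the measured compounds shown here, compound 1 gives 920 nM in this assay, and since compound 1 and compound 2 differ in more than one place, no single step between them is drawn.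

Compound 3 `O=C1c2c[n+]([O-])c3ccccc3c2C(=O)c2c1c1ccccc1n2Cc1cn([C@@H]2O[C@H](CO)[C@@H](O)[C@H](O)[C@H]2O)nn1` has not yet been measured. It differs from compound 2 by 3,4,5-trihydroxy-6-(hydroxymethyl)oxan-2-yl in place of (5-(hydroxymethyl)-2,2-dimethyl-1,3-dioxolan-4-yl)methyl on an aromatic nitrogen. Because compound 2 sits at the limit of > 1000 nM, there is no measured value from which a step can be counted, and nothing among the two measured compounds points toward stronger inhibition after this exchange. For compound 3 the expected step is a step that the limit leaves unreadable from compound 2 to compound 3, most likely none beyond the scatter or a modest move toward weaker inhibition. Compound 3 is accordingly estimated at 3000 nM in this assay, with a range from 800 nM to 15000 nM, and a good chance that the assay again reports only a limit.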

Compound 3, half-maximal inhibitory concentration: 880 nM
Estimate against measurement, compound 3: 3.4-fold (0.53 log units) above; the measured number falls inside the stated range.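

The exchange gives this position its first measured number: with 3,4,5-trihydroxy-6-(hydroxymethyl)oxan-2-yl in place of (5-(hydroxymethyl)-2,2-dimethyl-1,3-dioxolan-4-yl)methyl on the aromatic nitrogen, compound 3 gives 880 nM in this assay, a reading and not a limit. The change amounts to an at least 1.1-fold lower number from compound 2 to compound 3 (0.05 log units; that floor lies within the scatter), so the data show no step beyond the scatter, yet they do not rule out a larger one. Only a floor can be given because compound 2 stands at a limit and has no number of its own: the limit of > 1000 nM in this assay, at which 1 of the 3 values shown sits.

The true size of the step stays open, and the compounds shown cannot separate the part played by the six-membered non-aromatic ring from that of its hydroxyl groups. Also open, as far as these compounds go, is how a primary amine, a carboxylic acid or a plain butyl chain would read on the same aromatic nitrogen of the five-membered ring, where each would replace the 3,4,5-trihydroxy-6-(hydroxymethyl)oxan-2-yl group of compound 3 and leave the rest of the molecule unchanged.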